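A few compounds are considered here, and "the series" means these few. Any claim that something is new, unique, unknown or untested is made for them only; others in the source may bear on it.

In a functional assay on the whole organism (strain albino) with Rattus norvegicus as the target, in the maximal electroshock model, with a stated time of 1 h, at a dose of 30 mg/kg by the intraperitoneal route (a higher number here means more inhibition at the dose given (going by the name of the read-out), a lower number less inhibition), compound 1 `Cc1nc2ccc(Br)cc2c(=O)n1NCc1nnc(/N=C/c2ccc(N(C)C)cc2)s1` gives 50%. Compound 2 `COc1ccc(/C=N/c2nnc(CNn3c(C)nc4ccc(Br)cc4c3=O)s2)cc1` carries methoxy in place of dimethylamino on an aromatic carbon and in this assay compound 2 gives 50%, so that no change at the digits printed from compound 1 to compound 2 (within the scatter). Compound 3 `Cc1nc2ccccc2c(=O)n1NCc1nnc(N2C(=O)CSC2c2ccc(N(C)C)cc2)s1` rests on a different core; how the core of compound 3 differs from the core of compound 1 is not broken down here. In this assay compound 3 gives 60%, and its gaps to compound 1 and to compound 2 lie within the scatter, so no order among the three can be read from these numbers.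

Compound 4 `COc1ccc(C2SCC(=O)N2c2nnc(CNn3c(C)nc4ccccc4c3=O)s2)cc1` has not yet been measured. It differs from compound 3 by methoxy in place of dimethylamino on an aromatic carbon, the same change that separates compound 1 from compound 2, at a place described in the same words. Because no change at the digits printed from compound 1 to compound 2 (within the scatter) on the core of compound 1, the same change on the core of compound 3 is expected to give no change at the digits printed from compound 3 to compound 4 (within the scatter). That expectation rests on a single earlier pair, and the two cores are not the same. Compound 4 is therefore estimated at 60%, with an expected range from 45% to 75%.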

Compound 4, a percentage reported as inhibition, in the whole organism at one dose (the size of the read-out at that dose, not a potency): 60%
The estimate for compound 4 equals the measured number at the digits printed; the range from low to high includes it.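

Methoxy in place of dimethylamino on the aromatic carbon gives, in this assay, no change at the digits printed from compound 3 to compound 4 (within the scatter), and set beside the earlier step it reads as follows: the same change on two cores in this assay, no change at the digits printed (within the scatter) from compound 1 to compound 2 and no change at the digits printed (within the scatter) from compound 3 to compound 4, 0 percentage points apart, within the scatter of two such steps. Within these two pairs, then, the change carries from the core of compound 1 to the core of compound 3 with no difference that can be told from the scatter. This does not show that the two groups are interchangeable in general: a step that leaves the number in place on both cores is only a weak test of transfer, the read-out is a size at one dose and not a potency, and two pairs say nothing about a third core.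

The compounds shown leave open whether another group at this place, such as a chlorine, a nitro group or a carboxylic acid, would move the number beyond the scatter. They also leave open what a longer chain on the oxygen of the methoxy group would do on either core.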